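The compounds below may be only part of what the source reports. "The series", "measured", "known", "first", "only" and "open" are said of these compounds alone.

In a functional assay on UACC-62 cells (Homo sapiens) (a higher number here means a weaker inhibitor of growth, a lower number a stronger inhibitor of growth), compound 3 `O=S(=O)(/C=C/c1ccc(Cl)c(Cl)c1)Cc1ccc(Nc2ncnc3ccc(Br)cc23)cc1` gives 30000 nM, within the scatter of compound 1 `O=S(=O)(/C=C/c1ccc(Cl)c(Cl)c1)Cc1ccc(Nc2ncnc3ccccc23)cc1` at 21000 nM and a higher number than compound 2 `O=S(=O)(/C=C/c1ccc(Cl)cc1)Cc1ccc(Nc2ncnc3ccccc23)cc1` at 13000 nM. Compound 4 `O=S(=O)(/C=C/c1ccc(Cl)cc1)Cc1ccc(Nc2ncnc3ccc(Br)cc23)cc1` differs from compound 3 by hydrogen in place of chloro on an aromatic carbon, so that 3,4-dichlorophenyl becomes 4-chlorophenyl. The same exchange without the bromo group gives a 1.6-fold lower number from compound 1 to compound 2 (0.21 log units; within the scatter), and adding the bromo group gives a 1.4-fold higher number from compound 1 to compound 3 (0.15 log units; within the scatter); both lie within the scatter. In this assay the expected result is therefore a small move to a lower number, with no step beyond the scatter: the estimate is a 1.6-fold lower number from compound 3 to compound 4 (0.20 log units; within the scatter). Compound 4 is expected at 19000 nM, with an estimated range of 10000 nM to 34000 nM.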

Compound 4, concentration for 50% growth inhibition: 15000 nM
Beside the measured number, compound 4's estimate is 1.3-fold (0.10 log units) above it; measured number inside the range.
By their numbers in this assay, from the lowest: compounds 2, 4, 1 and 3 (each within the scatter of the next, the first and the last beyond it).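

In this assay, the change from 3,4-dichlorophenyl to 4-chlorophenyl now also reads with the bromo group present, giving a 2.0-fold lower number from compound 3 to compound 4 (0.30 log units; within the scatter), and its size holds across both cores: the same change on two cores in this assay, a 1.6-fold lower number (0.21 log units; within the scatter) from compound 1 to compound 2 and a 2.0-fold lower number (0.30 log units; within the scatter) from compound 3 to compound 4, 1.2-fold (0.09 log units) apart, within the scatter of two such steps. The bromo group now also reads with 4-chlorophenyl in place, giving a 1.2-fold higher number from compound 2 to compound 4 (0.06 log units; within the scatter), and it too stays small on both cores: the same change on two cores in this assay, a 1.4-fold higher number (0.15 log units; within the scatter) from compound 1 to compound 3 and a 1.2-fold higher number (0.06 log units; within the scatter) from compound 2 to compound 4, 1.2-fold (0.09 log units) apart, within the scatter of two such steps. Across these four compounds, neither change moves the number beyond the scatter, whichever form the other position takes.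

Still open, as far as these compounds go, is whether a methoxy group or an amine on that aromatic carbon would give a step beyond the scatter. The same question stands for an amine or a carboxylic acid in place of the bromo group.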